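Benzamide series against the Substance-P receptor: next analogue

The source may hold more compounds than are shown below. What is called first, only, known or untested is meant among the compounds shown, and "the series" means these compounds.

Measured so far:
- compound 1 `FC(F)(F)c1cc(CNCc2ccccc2-c2ccccc2)cc(C(F)(F)F)c1`: 372 nM
- compound 2 `Cc1ccccc1-c1cnccc1C(=O)N(C)Cc1cc(C(F)(F)F)cc(C(F)(F)F)c1`: 4.6 nM
- compound 3 `Cc1ccccc1-c1ccccc1C(=O)N(C)Cc1cc(C(F)(F)F)cc(C(F)(F)F)c1`: 17 nM

In an assay on CHO cells for displacement of a labelled ligand from Substance-P receptor (Homo sapiens) (a higher number here means a weaker inhibitor, a lower number a stronger inhibitor), compound 3 gives 17 nM, the second highest of the three numbers. Compound 2 sits lower, beyond the scatter, and compound 1 sits higher, also beyond the scatter. Compound 4 `Cc1ccccc1-c1cc(N2CCN(C)CC2)ccc1C(=O)N(C)Cc1cc(C(F)(F)F)cc(C(F)(F)F)c1` is not yet measured. It differs from compound 3 in one place: 4-methylpiperazin-1-yl in place of hydrogen on an aromatic carbon. Among the measured compounds shown here, no measured pair shows this change, so its effect is unknown. In this assay a moderate step toward a lower number is expected, a 1.7-fold lower number from compound 3 to compound 4 (0.23 log units; within the scatter), since the added group extends the compound 3 scaffold without removing any part. Compound 4 is therefore estimated at 10 nM, with a range from 2.5 nM to 40 nM.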

Compound 4, inhibition constant: 1.4 nM
Compound 4: the middle estimate sits 7.1-fold (0.85 log units) above what was measured; measured number outside the range, below it.
By their numbers in this assay, from the lowest: compound 4; then compound 2; then compound 3; then compound 1.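

In this assay, among the compounds shown here, 4-methylpiperazin-1-yl in place of hydrogen on an aromatic carbon gives a 12-fold lower number from compound 3 to compound 4 (1.08 log units; beyond the scatter) and this is the only single-place step so far. The position para to a large group and meta to a 2-methylphenyl group therefore tolerates this added ring, and the number falls rather than rises. No measurement at hand bears on the reason for a step of this size. From the compounds shown here alone, whether the ring as a whole or its nitrogens carry the step stays open, and a morpholine or a dimethylamino group here would separate the two. Going by these compounds, whether the same change holds on the core of compound 2 also stays open.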